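This account rests on a few compounds, and the source may have more. Where it says the series, first, only, none or still open, it means among the compounds named here.

Measured in an assay on membranes from liver for displacement of a labelled ligand from Sigma intracellular receptor 2 (Rattus norvegicus), read by scintillation counting, with a stated time of 120 min; a higher number here means a weaker inhibitor, a lower number a stronger inhibitor:
Compound 1, `Cc1cccc2sc(NC(=O)CCN3CCN(C(C)C)CC3)nc12`, gives 1800 nM.
Compound 2, `Cc1cccc2sc(NC(=O)CCN3CCN(CCCN(C)C)CC3)nc12`, gives > 1000 nM; this is a limit of the assay, not a number.
Compound 3, `Cc1cccc2sc(NC(=O)CCN3CCN(CC4CCCCC4)CC3)nc12`, gives 519 nM.

Compound 3 holds the lowest of the two numbers read. Its nearest neighbour is compound 1, reached through a 3.5-fold lower number from compound 1 to compound 3 (0.54 log units; beyond the scatter); from compound 2 the step is an at least 1.9-fold lower number from compound 2 to compound 3 (0.28 log units; that floor lies within the scatter), and its floor does not clear the scatter. Compound 4, `Cc1cccc2sc(NC(=O)CCN3CCN(C4CCN(C)CC4)CC3)nc12`, is the next to be measured. It differs from compound 3 in one place: 1-methylpiperidin-4-yl in place of cyclohexylmethyl on an amine nitrogen in a ring.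

Two measured steps on the same ring nitrogen bear on this. Swapping one plain alkyl group for another gave a 3.5-fold lower number from compound 1 to compound 3 (0.54 log units; beyond the scatter). Attaching a chain that carries a further nitrogen gave a step that the limit leaves unreadable from compound 1 to compound 2, with compound 2 resting at the limit of > 1000 nM in this assay, at which 1 of the 3 values shown sits. The entering group is cyclic like cyclohexylmethyl yet carries a nitrogen like the chain in compound 2, so the number is expected to rise in this assay, though not necessarily all the way back to compound 1.

Compound 4 is expected to give 1200 nM in this assay, within 400 nM to 4000 nM. The expected step is a 2.3-fold higher number from compound 3 to compound 4 (0.36 log units; beyond the scatter), and a limit rather than a number is a real possibility.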

Compound 4, inhibition constant: 3600 nM
Beside the measured number, compound 4's estimate is 3.0-fold (0.48 log units) below it; low and high end bracket the measured number.
By their numbers in this assay, from the lowest: compound 3; then compounds 1 and 4 (each within the scatter of the next).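

In this assay, at this amine nitrogen in a ring, both the leaving and the entering group hold a six-membered non-aromatic ring, yet the 1-methylpiperidin-4-yl group, with its ring nitrogen and without the methylene link of cyclohexylmethyl, gives a 6.9-fold higher number from compound 3 to compound 4 (0.84 log units; beyond the scatter); a six-membered ring on this nitrogen is therefore not enough to keep the lower number of compound 3. Against the small isopropyl group, the same entering group gives a 2.0-fold higher number from compound 1 to compound 4 (0.30 log units; within the scatter), so this larger cyclic group cannot be told apart from isopropyl here, and among the readable values only cyclohexylmethyl stands clear of the others. The step between compound 2 and compound 4 cannot be read, as compound 2 rests at a limit of the assay, not a number: the limit of > 1000 nM in this assay, at which 1 of the 4 values shown sits.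

The compounds shown leave open whether the higher number of compound 4 follows the ring nitrogen or the direct attachment of the ring, which a cyclohexyl group or a 1-methylpiperidin-4-ylmethyl group on the same nitrogen would separate. Also open, on these data alone, is whether a tetrahydropyran-4-yl group, with a ring oxygen in place of that ring nitrogen, or a benzyl group would read closer to compound 3 or to compound 4.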